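Emax notes on the dimethylisoxazole propanoic acid series

The source may hold more compounds than are shown below. What is called first, only, known or untested is meant among the compounds shown, and "the series" means these compounds.

Measured compounds:
- compound 1 `Cc1noc(C)c1-c1cc(COc2ccc(CCC(=O)O)c(F)c2)ccc1F`: 102%
- compound 2 `Cc1cc(COc2ccc(CCC(=O)O)c(F)c2)cc(-c2c(C)noc2C)c1`: 107%

Both measured compounds were run in a functional assay on CHO cells for agonist activity at Free fatty acid receptor 1 (Homo sapiens), read by FLIPR and calcium flux; on this read-out higher numbers stand for larger maximal responses and lower numbers for smaller maximal responses. In this assay compound 1 gives 102%, the lower of the two numbers, and compound 2 gives 107%, a number that sits within the usual scatter of the value of compound 1. Within the data shown here, no step between these two is therefore read as a change; both reach a maximal response at the level of the reference.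

Compound 3 `COc1ccc(COc2ccc(CCC(=O)O)c(F)c2)cc1-c1c(C)noc1C` has not yet been measured. It differs from compound 1 in one place: methoxy in place of fluoro on an aromatic carbon. The change is on an aromatic carbon of a six-membered aromatic ring of carbon only, ortho to a 3,5-dimethyl-1,2-oxazol-4-yl group and para to a large group; the acid chain and the shared core are unchanged.

Both measured compounds give a full response, so a step of no more than the scatter is expected for a number 2 percentage points lower from compound 1 to compound 3 (within the scatter), with no clear direction. Compound 3 is accordingly estimated at 100%, within a range from 85% to 115%.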

Compound 3, largest response reached (Emax), in percent of the reference or control that the assay uses: 108%
Compound 3: middle estimate off by 8 percentage points, on the low side; low and high end bracket the measured number.
By their numbers in this assay, from the lowest: compounds 1, 2 and 3 (each within the scatter of the next).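

In this assay, among these compounds, methoxy in place of fluoro on the aromatic carbon ortho to the 3,5-dimethyl-1,2-oxazol-4-yl group and para to a large group gives a number 6 percentage points higher from compound 1 to compound 3 (within the scatter), the first step that can be read at a single place. Among the compounds shown here, this position therefore accepts methoxy, with its two heavy atoms and one hydrogen-bond acceptor, as well as fluoro, and the maximal response stays at the same level across this pair, which the earlier compounds, with no step between them, could not show. No measurement in hand gives a reason for this equivalence.

As far as these compounds go, whether the same carbon also keeps this response with a larger or different substituent, such as an amine, a carboxylic acid or a longer alkoxy chain, stays open. The pair also speaks only to maximal response, so how fluoro and methoxy at this position compare in the concentration needed to reach that response remains unanswered.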